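The source may report more compounds than this note shows. Statements on the series, on what has been measured and on what is new or still open speak of the compounds shown alone.

Measured compounds and their readings:
- compound 1, `COc1ccccc1NC(=O)c1cscc1Sc1ccc([N+](=O)[O-])cc1`: 518000 nM
- compound 3, `COc1ccccc1NC(=O)c1cccnc1Sc1ccc([N+](=O)[O-])cc1`: 525000 nM
- compound 2, `COc1ccccc1NC(=O)c1cc([N+](=O)[O-])ccc1Sc1ccc([N+](=O)[O-])cc1`: "not determined" (no result reported)

The readings come from an ADME assay on H9 cells (Homo sapiens) for cytotoxicity, read by MTT assay, with a stated time of 7 days; a higher number here means that more compound is tolerated, a lower number that less compound is tolerated. In this assay compound 1 gives 518000 nM and compound 3 gives 525000 nM, two values that sit within the usual scatter of each other, so no order can be read between them. Compound 2 carries a nitro group on its central ring and has no result in this assay, so it stands on no number here; all that can be said is that the two compounds around it both tolerate a great deal of material before cell killing sets in.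

Compound 4, `COc1ccccc1NC(=O)c1cc(N(C)C)ccc1Sc1ccc([N+](=O)[O-])cc1`, takes one step away from compound 2: dimethylamino in place of nitro on an aromatic carbon. Within the data shown here, no measured pair shows what such a step does here, so the expectation can rest only on compounds 1 and 3. A step no larger than the scatter, in either direction, seems the most likely outcome. Compound 4 is therefore expected to give about 400000 nM in this assay, with a range estimated from 150000 nM to 1000000 nM.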

Compound 4, half-maximal cytotoxic concentration: 182000 nM
Estimate against measurement, compound 4: 2.2-fold (0.34 log units) above; the range from low to high includes it.
By their numbers in this assay, from the lowest: compound 4; then compounds 1 and 3 (each within the scatter of the next).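

In this assay compound 2 has no number, so the change from compound 2 to compound 4 cannot be read as a step. What replacing nitro with dimethylamino does to the tolerated concentration stays open, and nothing shown offers an explanation for the reading of compound 4.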